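Single-concentration cytotoxicity: methoxy to hydroxy step

A few compounds are considered here, and "the series" means these few. Any claim that something is new, unique, unknown or untested is made for them only; others in the source may bear on it.

Of the compounds shown here, three have been measured in a functional assay on A549 cells (Homo sapiens) for cytotoxicity, read by sulforhodamine B assay, with a stated time of 48 h, tested at 0.01 uM; on this read-out lower numbers stand for a stronger effect and higher numbers for a weaker effect at the one concentration tested. Compound 1 `COc1cc(C)cc(-c2nn(CC#N)cc2-c2ccc(-c3cccc(C(C)=O)c3)nc2)c1` gives 87% in this assay; compound 2 `Cc1cc(O)cc(-c2nn(CC#N)cc2-c2ccnc(-c3ccc(Oc4ccccc4)cc3)c2)c1` gives 88%; compound 3 `COc1cc(C)cc(-c2nn(CC#N)cc2-c2ccnc(-c3ccc(N(C)C)cc3)c2)c1` gives 97%. Compound 3 shows the highest of the three numbers, but compound 2 lies within the scatter of it, and so does compound 1, so no order among the three can be drawn. All three numbers sit close to the upper end of the read-out, that is, a weak effect at the concentration tested.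

Compound 4 `Cc1cc(O)cc(-c2nn(CC#N)cc2-c2ccnc(-c3ccc(N(C)C)cc3)c2)c1` is the next compound to be run. It differs from compound 3 in one place: hydrogen in place of methyl on an oxygen on an aromatic ring Cut one bond further out, the change reads methoxy to hydroxy. Compound 2 also carries hydroxy rather than methoxy, though it differs from compound 4 elsewhere as well, and its value is within the scatter of compound 3. Among the measured compounds shown here, no step between two measured compounds separated by this change alone is available.

The step expected is a number 5 percentage points lower from compound 3 to compound 4 (within the scatter), which amounts to nothing beyond the scatter, in no particular direction. Compound 4 is therefore estimated at 92%, in a range from 80% to 100%.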

Compound 4, a percentage reported as activity, at one concentration (the size of the read-out at that concentration, not a potency): 91%
Estimate against measurement, compound 4: 1 percentage points above; the measured number falls inside the stated range.
By their numbers in this assay, from the lowest: compounds 1, 2, 4 and 3 (each within the scatter of the next).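

In this assay, the change from methoxy to hydroxy can now be read on its own, with the rest of the structure held fixed: it gives a number 6 percentage points lower from compound 3 to compound 4 (within the scatter). At this one concentration, hydrogen in place of methyl on the oxygen therefore has no readable effect on the 3-methoxy-5-methylphenyl group when dimethylamino is present, and the second pair, with dimethylamino in place of phenoxy on an aromatic carbon and the hydroxy kept, gives a number 3 percentage points higher from compound 2 to compound 4 (within the scatter), so that exchange is equally unreadable here. No measured evidence bears on these two results, and nothing can be said about what lies behind them.

As far as these compounds go, all four compounds sit near the upper end of the read-out at a single concentration, so it stays open whether either change would separate the compounds at a concentration where the effect is stronger. From the compounds shown here alone, it also stays open whether a longer chain on the oxygen, such as ethoxy, or an amine in place of the hydroxy would move the number beyond the scatter.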